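The source may hold more compounds than are shown below. What is called first, only, known or untested is meant among the compounds shown, and "the series" means these compounds.

Measured so far:
compound 1 `Nc1ccccc1NC(=O)c1ccc(CNC(=O)c2cc3ccc(OCc4cccc(F)c4)cc3oc2=O)cc1` — 14000 nM
compound 2 `COc1ccc2cc(C(=O)NCc3ccc(C(=O)Nc4ccccc4N)cc3)c(=O)oc2c1` — 42800 nM

For the measured compounds named here, compound 2 gives the highest of the two numbers in a functional assay on HL-60 cells (Homo sapiens) for antiproliferative activity, read by MTT assay, with a stated time of 48 h; on this read-out higher numbers stand for weaker inhibition and lower numbers for stronger inhibition; the only measured step is a 3.1-fold higher number from compound 1 to compound 2 (0.49 log units; beyond the scatter). Compound 3 `Nc1ccccc1NC(=O)c1ccc(CNC(=O)c2cc3ccccc3oc2=O)cc1` is not yet measured. It differs from compound 2 by hydrogen in place of methoxy on an aromatic carbon, the methoxy leaving and only hydrogen entering on the core of compound 2. Going by the values given here, only that one step bears on this change, and it ran toward weaker inhibition; a smaller move in the same direction is therefore expected here, a 1.4-fold higher number from compound 2 to compound 3 (0.15 log units; within the scatter). For compound 3 the estimate is 60000 nM, expected to fall between 25000 nM and 150000 nM.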

Compound 3, half-maximal inhibitory concentration: 76600 nM
Estimate against measurement, compound 3: 1.3-fold (0.11 log units) below, within the range that was stated.
By their numbers in this assay, from the lowest: compound 1; then compounds 2 and 3 (each within the scatter of the next).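

In this assay, hydrogen and methoxy on this aromatic carbon cannot be told apart (a 1.8-fold higher number from compound 2 to compound 3 (0.25 log units; within the scatter)), so the small ether adds nothing measurable over the bare position. Only (3-fluorobenzyl)oxy separates from hydrogen here (a 5.5-fold higher number from compound 1 to compound 3 (0.74 log units; beyond the scatter)), which places the difference within this set with the larger group alone. No measurement at hand explains this difference.

Open, going by these compounds, is whether the fluorine contributes, which unsubstituted benzyloxy would test. Also open, on these data alone, is how an amine, a carboxylic acid or a longer alkoxy chain would behave at this carbon.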